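Working notes: from compound 2 to compound 3

The source may report more compounds than this note shows. Statements on the series, on what has been measured and on what is new or still open speak of the compounds shown alone.

Measured in an ADME assay on Vero cells (Chlorocebus sabaeus) for cytotoxicity, read by reporter gene assay, with a stated time of 4 days; a higher number here means a weaker inhibitor, a lower number a stronger inhibitor:
- compound 1 `CCCCCCCCCCCCCCCCCC(=O)NCC(C)(C)CC1=C(O)C(=O)c2ccccc2C1=O`: 5760 nM
- compound 2 `CCCCCCCC(=O)OCC(C)(C)CC1=C(O)C(=O)c2ccccc2C1=O`: > 258000 nM

Compound 2 has no exact value, and its entry of > 258000 nM is a limit of the assay. Compound 1 gives a measured number of 5760 nM. Among the compounds with values here, the two compounds differ in more than one place, and no measured step isolates a single change.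

The next compound is compound 3 `CCCCCCCCCCCCCC(=O)OCC(C)(C)CC1=C(O)C(=O)c2ccccc2C1=O`, still to be tested in this assay. It carries one change from compound 2: hexyl in place of hydrogen on a saturated chain carbon, seven bonds along the chain from a carbonyl carbon. Within the data shown here, with only two measured compounds, any expectation here is loose. Among the measured compounds shown here, a shift towards a lower number is expected, resting on compound 1 at 5760 nM, the only measured compound with a number. A reading that again returns only a limit remains quite possible.

The expected change is an at least 3.6-fold lower number from compound 2 to compound 3 (0.56 log units; beyond the scatter).

For compound 3 the estimate is 70000 nM, with an expected range of 10000 nM to 250000 nM.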

Compound 3, half-maximal inhibitory concentration: 58400 nM
Estimate against measurement, compound 3: 1.2-fold (0.08 log units) above; low and high end bracket the measured number.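

In this assay, within the data shown here, hexyl in place of hydrogen on a saturated chain carbon, seven bonds along the chain from a carbonyl carbon, gives an at least 4.4-fold lower number from compound 2 to compound 3 (0.64 log units; beyond the scatter), the first single change that can be read. This shows that the ester chain is not a silent position in this assay, and compound 3 is the first ester shown with a measured number, 58400 nM. The size of the step is only a lower bound, since compound 2 stands at a limit of the assay rather than at a number: the limit of > 258000 nM in this assay, at which 1 of the 3 values shown sits.

Going by these compounds, whether the lower number of compound 1, 5760 nM, belongs to its longer chain or to its amide linkage stays open, since compound 1 differs from compound 3 in more than one place. An amide carrying the chain of compound 3, an ester carrying the longer chain of compound 1, or a carboxylic acid at the chain end would each test one of these places alone and show whether the change continues along the chain.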